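The source may hold more compounds than are shown below. What is called first, only, known or untested is meant among the compounds shown, and "the series" means these compounds.

Within the data shown here, in a functional assay on SW1990 cells (Homo sapiens) for cytotoxicity, read by MTT assay, with a stated time of 48 h (a higher number here means a weaker inhibitor, a lower number a stronger inhibitor), compound 1 `O=C(c1ccc2cccc(OCc3ccc(B(O)O)cc3)c2n1)N1CCC(Oc2no[n+]([O-])c2S(=O)(=O)c2ccccc2)CC1` gives 12900 nM and compound 2 `CC1(C)OB(c2ccc(COc3cccc4ccc(C(=O)N5CCC(Oc6no[n+]([O-])c6S(=O)(=O)c6ccccc6)CC5)nc34)cc2)OC1(C)C` gives 12100 nM, so compound 1 stands level with its only measured neighbour. Compound 3 `O=C(c1ccc2cccc(O)c2n1)N1CCC(Oc2no[n+]([O-])c2S(=O)(=O)c2ccccc2)CC1` differs from compound 1 by a hydrogen atom in place of a group of 10 heavy atoms (7 carbon, 1 boron, 2 oxygen; one six-membered aromatic ring of carbon only), on an oxygen on an aromatic ring, leaving a hydrogen atom on an oxygen on an aromatic ring. Among the measured compounds shown here, the one measured step, a 1.1-fold lower number from compound 1 to compound 2 (0.03 log units; within the scatter), changes only the end of this group, so it says little about removing the group altogether. A modest move towards a stronger inhibitor is expected in this assay, with wide uncertainty, and the expected step is a 2.2-fold lower number from compound 1 to compound 3 (0.33 log units; beyond the scatter). Compound 3 is estimated at 6000 nM, with an expected range of 2000 nM to 15000 nM.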

Compound 3, half-maximal inhibitory concentration: 6590 nM
For compound 3 the middle estimate is 1.1-fold (0.04 log units) below the measured one; low and high end bracket the measured number.
By their numbers in this assay, from the lowest: compounds 3, 2 and 1 (each within the scatter of the next).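

Taking the whole group off the oxygen gives a 2.0-fold lower number from compound 1 to compound 3 (0.29 log units; within the scatter) in this assay and, unlike the earlier change at the far end of the group, this tests the group as a whole. The core of compound 1 thus keeps a comparable reading in these cells with only a hydrogen on that oxygen. No measurement at hand explains this result. Still open, going by these compounds, is whether a small group on this oxygen, such as a methyl or an aminoethyl chain, would read differently from the hydrogen of compound 3.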